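This account rests on a few compounds, and the source may have more. Where it says the series, first, only, none or still open, it means among the compounds named here.

Of the compounds shown here, three have been measured in a functional assay on KB cells (Homo sapiens) for antiproliferative activity, read by MTT assay, with a stated time of 72 h; a lower number here means a stronger inhibitor, a higher number a weaker inhibitor: compound 1 `CN(C(=O)c1ccccc1)c1ccc2[nH]c(-c3n[nH]c4ccccc34)cc2n1` gives 8580 nM, compound 2 `CN(C(=O)c1ccco1)c1ccc2[nH]c(-c3n[nH]c4ccccc34)cc2n1` gives 19400 nM, and compound 3 `CN(C(=O)c1ccccc1)c1ccc2[nH]c(-c3n[nH]c4cc(Cl)ccc34)cc2n1` gives 5590 nM.

Compound 1 sits second highest of the three. Its nearest neighbour is compound 3, and that step, a 1.5-fold lower number from compound 1 to compound 3 (0.19 log units; within the scatter), lies within the scatter; its furthest neighbour is compound 2, with a 2.3-fold higher number from compound 1 to compound 2 (0.35 log units; beyond the scatter).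

Compound 4 `CN(c1ccc2[nH]c(-c3n[nH]c4ccccc34)cc2n1)S(=O)(=O)c1ccc(Cl)cc1` differs from compound 1 in one place: (4-chlorophenyl)sulfonyl in place of benzoyl on a nitrogen on an aromatic ring. Within the data shown here, no measured step replaces the benzoyl group with a sulfonyl group. The step that changed the ring on the carbonyl carbon was modest, and the step that added a chloro stayed within the scatter. The expected step is therefore modest, a 1.0-fold higher number from compound 1 to compound 4 (0.02 log units; within the scatter), with the direction uncertain. Compound 4 is expected to give 9000 nM, in a range from 3500 nM to 25000 nM.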

Compound 4, half-maximal inhibitory concentration: 8350 nM
For compound 4 the middle estimate is 1.1-fold (0.03 log units) above the measured one, and the stated range covers the measured number.
By their numbers in this assay, from the lowest: compounds 3, 4 and 1 (each within the scatter of the next); then compound 2.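

On a nitrogen on an aromatic ring, (4-chlorophenyl)sulfonyl replaces benzoyl with no readable change (a 1.0-fold lower number from compound 1 to compound 4 (0.01 log units; within the scatter)), so a carbonyl at this place is not required for a number of this size in this assay. Set against the (furan-2-yl)carbonyl group, the same sulfonyl group gives a modest step beyond the scatter (a 2.3-fold lower number from compound 2 to compound 4 (0.37 log units; beyond the scatter)). Nothing measured here explains these results.

As far as these compounds go, what the sulfonyl link and the chloro each contribute alone remains open. So does whether an amine-bearing chain on this nitrogen would keep the number.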